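Bromo in place of ethyl on a dichlorotriazine aniline

The source may report more compounds than this note shows. Statements on the series, on what has been measured and on what is new or still open speak of the compounds shown alone.

Three compounds built around a dimethoxy- or dichlorotriazine were tested in an assay for inhibition of Pro-cathepsin H (Homo sapiens), read by fluorescence, tested at 50 uM; on this read-out lower numbers stand for less inhibition and higher numbers for more inhibition at the one concentration tested (going by the name of the read-out). Compound 1, `COc1nc(OC)nc(Sc2ccccc2C(=O)O)n1`, gives -14.3% in this assay. Compound 2, `COC(=O)c1ccccc1Oc1nc(OC)nc(OC)n1`, gives -5.34%. Compound 3, `CCc1ccccc1Nc1nc(Cl)nc(Cl)n1`, gives -2.26%, which stands beyond the scatter above compound 1 and within the scatter of compound 2; none of the three shows appreciable inhibition at the concentration tested.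

Compound 4, `Clc1nc(Cl)nc(Nc2ccccc2Br)n1`, is compared with compound 3. The change is bromo in place of ethyl on an aromatic carbon, made on an aromatic carbon of a six-membered aromatic ring of carbon only, ortho to a group of 9 heavy atoms. For the measured compounds named here, no pair of measured compounds differing in one place is available, so the size of this kind of step in this assay is unknown here.

Since compound 3 sits at -2.26% and compounds 1 and 2 likewise lie near zero, compound 4 is expected to show no inhibition beyond the scatter, with a step of a number 0.7 percentage points lower from compound 3 to compound 4 (within the scatter). The estimate for compound 4 is -3%, within a range from -16% to 10%.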

Compound 4, a percentage reported as inhibition, at one concentration (the size of the read-out at that concentration, not a potency): 4.52%
The estimate for compound 4 lay 7.5 percentage points below the measured number; the measured number falls inside the stated range.
By their numbers in this assay, from the lowest: compounds 1, 2, 3 and 4 (each within the scatter of the next, the first and the last beyond it).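

In this assay, the change from ethyl to bromo gives a number 6.8 percentage points higher from compound 3 to compound 4 (within the scatter), the first step read at this place, on an aromatic carbon ortho to a group of 9 heavy atoms. The two-carbon ethyl can thus give way to a single bromine without the reading moving beyond the usual scatter, so this one exchange does not set the two compounds apart. Nothing available here bears on why the two compounds read as they do.

The compounds shown leave open whether another group at this place, such as an amine, a carboxylic acid or a longer chain, would move the reading beyond the scatter. They also leave open whether bromo in place of ethyl would read the same way on a different core.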